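Trimming the Amide Substituent of Compound 1

This account rests on a few compounds, and the source may have more. Where it says the series, first, only, none or still open, it means among the compounds named here.

Measured so far in a functional assay on BXPC-3 cells (Homo sapiens) for inhibition, read by MTT assay, with a stated time of 7 days; on this read-out lower numbers stand for stronger inhibition and higher numbers for weaker inhibition:
Compound 1 `CCN(CC)S(=O)(=O)c1ccc(S(=O)(=O)N2CCC[C@@H](C(=O)N[C@@H]3CCN(C(=O)OC(C)(C)C)C3)C2)cc1` gives 400 nM.
Compound 2 `CCOC(=O)C12CC(CN(S(=O)(=O)c3ccc(S(=O)(=O)N(CC)CC)cc3)C1)C2` gives 1200 nM.
Compound 3 `CCOC(=O)[C@@H]1CCCN(S(=O)(=O)c2ccc(S(=O)(=O)N3CCNCC3)cc2)C1` gives > 30000 nM, which is a limit of the assay and not a number.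

Compound 1 holds the lower of the two numbers; compound 2 sits higher, beyond the usual scatter. Compound 4 `CCN(CC)S(=O)(=O)c1ccc(S(=O)(=O)N2CCC[C@@H](C(=O)NC)C2)cc1` differs from compound 1 in one place: methyl in place of 1-(tert-butoxycarbonyl)pyrrolidin-3-yl on an amide-type nitrogen. Among the measured compounds shown here, no measured pair in this set shows this change, so the size of the step in this assay is open. Since a good part of the structure leaves and only a methyl enters, a weaker result is expected, with a step from compound 1 to compound 4 estimated at a 5.0-fold higher number from compound 1 to compound 4 (0.70 log units; beyond the scatter). Compound 4 is therefore expected to give about 2000 nM, between 600 nM and 8000 nM.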

Compound 4, half-maximal inhibitory concentration: 13800 nM
For compound 4 the middle estimate is 6.9-fold (0.84 log units) below the measured one; measured number above the stated range.
By their numbers in this assay, from the lowest: compound 1; then compound 2; then compound 4. At a limit, above all of these: compound 3.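

Putting methyl in place of 1-(tert-butoxycarbonyl)pyrrolidin-3-yl on an amide-type nitrogen brings a 35-fold higher number from compound 1 to compound 4 (1.54 log units; beyond the scatter) in this assay. This position therefore matters, and much of the strength of compound 1 depends on the group that leaves. Compound 4 still gives a number and not a limit, so the full size of the step can be read: the limit of > 30000 nM in this assay, at which 1 of the 4 values shown sits.

Which part of the departing group counts stays open. A pyrrolidin-3-yl group with a free ring amine, or a longer chain such as butyl, would help separate the ring from the tert-butoxycarbonyl group.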